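Compound 3 and the 4-bromophenyl exchange

The source may hold more compounds than are shown below. What is called first, only, known or untested is meant among the compounds shown, and "the series" means these compounds.

Values in a functional assay on A549 cells (Homo sapiens) for cytotoxicity, read by MTT assay, with a stated time of 24 h (a higher number here means a weaker inhibitor, a lower number a stronger inhibitor), so far:
Compound 1 `COc1cc(/C=C(\C#N)C(=O)N/N=C(\C)c2c(O)c3ccc(O)cc3oc2=O)ccc1O` gives 12600 nM
Compound 2 `COc1cc(/C=C(\C#N)C(=O)N/N=C(\C)c2c(O)c3ccc(O)cc3oc2=O)cc(OC)c1OC` gives 15300 nM

Compound 1 stands within the scatter of compound 2, so these two numbers do not rank the pair. Compound 3 `C/C(=N\NC(=O)/C(C#N)=C/c1ccc(Br)cc1)c1c(O)c2ccc(O)cc2oc1=O` has not yet been measured. Its difference from compound 1 is 4-bromophenyl in place of 4-hydroxy-3-methoxyphenyl on a double-bonded chain carbon bound to a double-bonded chain carbon and amounts to 4-bromophenyl in place of 4-hydroxy-3-methoxyphenyl on a double-bonded chain carbon bound to a double-bonded chain carbon.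

For the measured compounds named here, no pair of measured compounds differs in one place, so no measured step shows what such an exchange does in this assay and the expectation rests on thin ground. Going by the values given here, the only guide is that compound 1 at 12600 nM and compound 2 at 15300 nM lie within the scatter of each other. No shift beyond the scatter is expected, and no direction is favoured. The estimated step is a 1.1-fold lower number from compound 1 to compound 3 (0.06 log units; within the scatter) and it is expected to be small, with wide uncertainty. In this assay the estimated value for compound 3 is 11000 nM with an expected range (4500 nM to 26000 nM).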

Compound 3, half-maximal inhibitory concentration: 11400 nM
Beside the measured number, compound 3's estimate is 1.0-fold (0.02 log units) below it; the measured number falls inside the stated range.
By their numbers in this assay, from the lowest: compounds 3, 1 and 2 (each within the scatter of the next).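

In this assay, the series now has its first readable single-place exchange, which gives a 1.1-fold lower number from compound 1 to compound 3 (0.04 log units; within the scatter) with 4-bromophenyl in place of 4-hydroxy-3-methoxyphenyl on a double-bonded chain carbon bound to a double-bonded chain carbon. The leaving group carries hydrogen-bond donors and acceptors and the entering group carries neither, yet the step stays within the scatter, so for this one pair these features of the aromatic group are not needed to keep the number at this level. No measurement accompanies this pair that could explain the result.

On these data alone, whether a basic amine, a carboxylic acid or a longer alkyl chain in place of the aromatic group at this position would produce a step beyond the scatter in this assay remains open. The shared core is the same in all the compounds shown, so the effect of any change there, and whether any change in this series can separate compounds in this assay at all, also remains open.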